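Hydroxamic acid series: dropping the aryl chloro

The compounds below may be only part of what the source reports. "The series", "measured", "known", "first", "only" and "open" are said of these compounds alone.

Compound 1 `O=C(CCC1CCCC1)N(O)c1ccc(Cl)cc1` gives 20000 nM in a functional assay on HEp-2 cells (Homo sapiens) for inhibition; on this read-out lower numbers stand for stronger inhibition and higher numbers for weaker inhibition.
Compound 2 `O=C(CC1CCCCC1)N(O)c1ccc(Cl)cc1` gives 9000 nM in this assay.

Within the data shown here, compound 2 holds the lower of the two numbers in this assay; the only measured step is a 2.2-fold lower number from compound 1 to compound 2 (0.35 log units; beyond the scatter), a modest move on the saturated chain at the carbonyl. Compound 3 `O=C(CC1CCCCC1)N(O)c1ccccc1` differs from compound 2 by hydrogen in place of chloro on an aromatic carbon. Among the measured compounds shown here, no measured step touches the aromatic ring, so nothing here speaks to the direction of this change. Compound 3 is therefore expected close to compound 2, the estimated step being a 1.3-fold higher number from compound 2 to compound 3 (0.12 log units; within the scatter). The estimate for compound 3 in this assay is 12000 nM, with a range of 4000 nM to 40000 nM.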

Compound 3, half-maximal inhibitory concentration: > 100000 nM
Compound 3: no number, only a limit (the forecaster's own chance of this, stated with the estimate: 20%); middle value at least 8.3-fold (0.92 log units) from the limit.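

In this assay, hydrogen in place of chloro on an aromatic carbon para to a large group gives an at least 11-fold higher number from compound 2 to compound 3 (1.04 log units; beyond the scatter). Among these compounds, this is the first sign that the chloro matters in this pair, and the move is larger than the modest 2.2-fold lower number from compound 1 to compound 2 (0.35 log units; beyond the scatter) on the saturated chain. The result for compound 3 is a limit and not a number: the limit of > 100000 nM in this assay, at which 1 of the 3 values shown sits.

The compounds shown leave open whether fluoro, methoxy or a nitrile at this place would keep the number of compound 2. Going by these compounds, whether the same change has a similar size with the chain of compound 1 also stays open.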